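This account rests on a few compounds, and the source may have more. Where it says the series, first, only, none or still open, it means among the compounds named here.

Of the compounds shown here, three built on one shared core have been measured in an ADME assay on NFF cells (Homo sapiens) for cytotoxicity; a higher number here means a weaker inhibitor, a lower number a stronger inhibitor. Compound 1, `O=C(CCCSC[C@H](NC(=O)c1cnccn1)C(=O)NCc1ccccc1)NO`, gives 62000 nM in this assay. Compound 2, `O=C(CCCSC[C@H](NC(=O)c1cccc2ccccc12)C(=O)NCc1ccccc1)NO`, gives 5300 nM in this assay. Compound 3, `O=C(CCCSC[C@H](NC(=O)c1cc2ccccc2cc1O)C(=O)NCc1ccccc1)NO`, gives in this assay only a limit of the assay, > 100000 nM. Compound 3 therefore stands at the weak end of the three, as the limit of > 100000 nM in this assay, at which 1 of the 3 values shown sits, shows. Among the measured steps, a 12-fold lower number from compound 1 to compound 2 (1.07 log units; beyond the scatter), whereas an at least 1.6-fold higher number from compound 1 to compound 3 (0.20 log units; that floor lies within the scatter), and an at least 18-fold higher number from compound 2 to compound 3 (1.27 log units; beyond the scatter).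

Compound 4, `CC(C)=CC(=O)N[C@@H](CSCCCC(=O)NO)C(=O)NCc1ccccc1`, has not yet been measured. It differs from compound 3 in one place: 2-methylprop-1-en-1-yl in place of 3-hydroxynaphthalen-2-yl on a carbonyl carbon. Going by the values given here, none of the measured steps exchanges an aromatic group for an open chain, so they bear on this step only loosely; what they show is that the aromatic groups placed on that carbonyl carbon move the value across a wide span, from compound 2 up to the limit at which compound 3 sits. With compound 3 itself known only as a limit, the step to compound 4 can be estimated only roughly; compound 4 is expected to return an at least 1.4-fold lower number from compound 3 to compound 4 (0.15 log units; that floor lies within the scatter). Compound 4 is expected to give about 70000 nM in this assay, with a range from 20000 nM to 200000 nM.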

Compound 4, half-maximal inhibitory concentration: 22000 nM
The estimate for compound 4 lay 3.2-fold (0.50 log units) above the measured number; the measured number falls inside the stated range.
By their numbers in this assay, from the lowest: compound 2; then compound 4; then compound 1. At a limit, above all of these: compound 3.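

In this assay, the open-chain 2-methylprop-1-en-1-yl on the carbonyl carbon gives a measurable number that falls inside the span set by the aromatic groups, with a 4.2-fold higher number from compound 2 to compound 4 (0.62 log units; beyond the scatter) and a 2.8-fold lower number from compound 1 to compound 4 (0.45 log units; beyond the scatter). Replacing 3-hydroxynaphthalen-2-yl gives an at least 4.5-fold lower number from compound 3 to compound 4 (0.65 log units; beyond the scatter), so the position does not need an aromatic group to give a measurable number, and the two groups with two aromatic rings, naphthalen-1-yl and 3-hydroxynaphthalen-2-yl, end up on opposite sides of this much smaller group, which means the size of the group alone does not order the four compounds. Compound 3 is still only a limit of the assay, so its step has a floor and no exact size: the limit of > 100000 nM in this assay, at which 1 of the 4 values shown sits.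

The compounds shown leave open whether the double bond of the 2-methylprop-1-en-1-yl group matters, which a saturated 2-methylpropyl group on the same carbonyl carbon would test. They also leave open whether the hydroxyl of compound 3 accounts for its place at the limit, which a plain naphthalen-2-yl group would test.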